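A few compounds are considered here, and "the series" means these few. Any claim that something is new, unique, unknown or untested is made for them only; others in the source may bear on it.

In a functional assay on the whole organism (strain Wistar) for inhibition, with Rattus norvegicus as the target, read by paw edema, with stated times of 30 min and 3 h, at a dose of 100 mg/kg by the oral route (a higher number here means a stronger effect of the compound at the dose given, a lower number a weaker effect), compound 2 `CCCNc1cnn(C)c(=O)c1OCC` gives 38%, the highest of the three numbers recorded. Compound 3 `C=CCN(CC=C)c1cnn(C)c(=O)c1OCC` gives 12.9%, a number that sits beyond the scatter below compound 2, and compound 1 `Cn1ncc(O)c(Cl)c1=O` gives -5.8%, further below still. Compound 4 `CCOc1c(N2CCCC2)cnn(C)c1=O` has not yet been measured in this assay. It differs from compound 2 in one place: pyrrolidin-1-yl in place of propylamino on an aromatic carbon. Within the data shown here, no step between two measured compounds follows this same change, so its size can only be judged from what is at hand. The closest point of reference is compound 3, which carries no hydrogen-bond donor at that position and in this assay gives 12.9%, a weaker result than compound 2. On that basis a downward step is expected, a number 18 percentage points lower from compound 2 to compound 4 (beyond the scatter) in this assay, though with the caution that one comparison is a thin foundation. Compound 4 is therefore estimated at 20%, with a range from 0% to 40%.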

Compound 4, a percentage reported as inhibition, in the whole organism at one dose (the size of the read-out at that dose, not a potency): 23%
Beside the measured number, compound 4's estimate is 3 percentage points below it; measured number inside the range.
By their numbers in this assay, from the lowest: compound 1; then compound 3; then compound 4; then compound 2.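

In this assay, among these compounds, the exchange of propylamino for pyrrolidin-1-yl, on an aromatic carbon ortho to an ethoxy group, gives a number 15 percentage points lower from compound 2 to compound 4 (beyond the scatter) and so provides the first direct reading of a single change at this position. The effect at this dose responds to the group held here but does not vanish, since compound 4 still gives 23% in this assay with the rest of the structure unchanged. The exchange removes the hydrogen-bond donor and brings in a five-membered non-aromatic ring at once, and no available evidence accounts for the step or tells these two differences apart.

Still open, as far as these compounds go, is which of the two differences goes with the lower number. A cyclopentylamino group would keep the ring together with the amine hydrogen, whereas a methyl(propyl)amino group would keep the open chain without that hydrogen, and the compounds shown include neither.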